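Fluoro for trifluoromethyl on the aryl piperazine

The source may hold more compounds than are shown below. What is called first, only, known or untested is meant among the compounds shown, and "the series" means these compounds.

Measured compounds:
compound 1 `CCC(C(=O)N1CCN(c2ccccc2Cl)CC1)N1C(=O)CCC1=O`: 50%
compound 2 `CCC(C(=O)N1CCN(c2cccc(F)c2)CC1)N1C(=O)CCC1=O`: 75%
compound 3 `CCC(C(=O)N1CCN(c2ccc(C(F)(F)F)cc2)CC1)N1C(=O)CCC1=O`: 0%

In a functional assay on the whole organism (strain Swiss) with Mus musculus as the target, in the maximal electroshock model, with a stated time of 1 h, at a dose of 300 mg/kg by the intraperitoneal route (on this read-out lower numbers stand for a weaker effect and higher numbers for a stronger effect at the one dose given), compound 3 gives 0%, the lowest of the three numbers, with compound 1 at 50% and compound 2 at 75% both beyond the scatter above it. Compound 4 `CCC(C(=O)N1CCN(c2ccc(F)cc2)CC1)N1C(=O)CCC1=O` differs from compound 3 by fluoro in place of trifluoromethyl on an aromatic carbon. For the measured compounds named here, the only measured step, a number 25 percentage points higher from compound 1 to compound 2 (beyond the scatter), concerns a change elsewhere on the ring and does not bear directly on this exchange; it shows only that a fluoro-bearing ring can give a strong read-out. Going by the values given here, with no close precedent, the step of a number 50 percentage points higher from compound 3 to compound 4 (beyond the scatter) is expected to run upward but is uncertain. Compound 4 is therefore estimated at 50%, with a range from 15% to 85%.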

Compound 4, a percentage reported as activity, at one dose (the size of the read-out at that dose, not a potency): 25%
The estimate for compound 4 lay 25 percentage points above the measured number; the range from low to high includes it.
By their numbers in this assay, from the lowest: compound 3; then compound 4; then compound 1; then compound 2.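

In this assay, fluoro in place of trifluoromethyl on an aromatic carbon recovers only part of the read-out (a number 25 percentage points higher from compound 3 to compound 4 (beyond the scatter)). The place of the fluoro on the ring also matters, since 4-fluorophenyl in place of 3-fluorophenyl gives the largest of these steps (a number 50 percentage points lower from compound 2 to compound 4 (beyond the scatter)), and 4-fluorophenyl in place of 2-chlorophenyl also lowers the number (a number 25 percentage points lower from compound 1 to compound 4 (beyond the scatter)). Nothing available explains these steps. The compounds shown leave open what a methoxy group or an amine would give on this aromatic carbon, and whether 2-fluorophenyl would match 3-fluorophenyl.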